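Adding a Chloro Group on a Phenyl Ring: Compound 4

This account rests on a few compounds, and the source may have more. Where it says the series, first, only, none or still open, it means among the compounds named here.

Compound 1 `Cc1nc(-c2ccc(Cl)cc2)sc1C1SCC(=O)N1c1ccc(F)c(Cl)c1` and compound 2 `Cc1nc(-c2ccc(Cl)cc2)sc1C1SCC(=O)N1c1ccc(F)cc1` share one core, while compound 3 `Cc1nc(Cc2ccc(Cl)cc2)sc1C1SCC(=O)N1c1ccccc1` and compound 4 `Cc1nc(Cc2ccc(Cl)cc2)sc1C1SCC(=O)N1c1ccc(Cl)cc1` share another; the difference between the two cores is not broken down here. All four belong to a functional assay on the whole organism (strain Wistar albino) for inhibition, with Rattus norvegicus as the target, read by paw edema, with a stated time of 1 h, at a dose of 40 mg/kg by the oral route; on this read-out lower numbers stand for less inhibition and higher numbers for more inhibition at the one dose given (going by the name of the read-out). In this assay compound 2 gives 63.4%, and compound 1 gives 53.4%. The step between them is a number 10 percentage points lower from compound 2 to compound 1 (within the scatter), and it comes from the change (chloro in place of hydrogen on an aromatic carbon). The change from compound 3 to compound 4 is the same kind of change, (chloro in place of hydrogen on an aromatic carbon), but not the same: in compound 1 the chloro sits ortho to a fluoro group and meta to a large group, whereas in compound 4 it sits para to a large group. In this assay compound 3 gives "not active" (no number reported), so no number stands as a starting point for the second step. Given that the earlier chloro step stayed within the scatter, the inhibition of compound 4 is expected to stay low because compound 3 is reported as "not active" (no number reported) in this assay. Compound 4 is therefore estimated at 20%, expected to fall between 0% and 45%.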

Compound 4, a percentage reported as inhibition, in the whole organism at one dose (the size of the read-out at that dose, not a potency): 48.9%
Beside the measured number, compound 4's estimate is 28.9 percentage points below it; the whole stated range lies below it.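

In this assay, going by these compounds alone, compound 3 is reported as "not active" (no number reported) and compound 4 gives 48.9% with no number on the compound 3 side, so no step between these two compounds can be read. The compounds shown leave open how large the change from phenyl to 4-chlorophenyl is on this core. No evidence on hand explains the result.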